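The source may report more compounds than this note shows. Statements on the series, on what has been measured and on what is new or still open speak of the compounds shown alone.

Of the compounds shown here, two built on a shared core have so far been tested in a functional assay on HeLa cells (Homo sapiens) for cytotoxicity, read by MTT assay; on this read-out higher numbers stand for weaker inhibition and lower numbers for stronger inhibition. Compound 1 (`CCC(O)CO[C@H](CC=C(C)C)C1=CC(=O)c2c(O)ccc(O)c2C1=O`) gives 28700 nM, while compound 2 (`CC(C)=CC[C@@H](OC(=O)CC(C)(O)c1ccccc1)C1=CC(=O)c2c(O)ccc(O)c2C1=O`) gives 85700 nM. Compound 2 therefore has the higher of the two numbers, and its gap to compound 1 lies beyond the usual scatter. Compound 3 (`CC(C)=CC[C@@H](OC(=O)c1ccoc1)C1=CC(=O)c2c(O)ccc(O)c2C1=O`) differs from compound 2 in one place, with furan-3-yl in place of 2-hydroxy-2-phenylpropyl on a carbonyl carbon. Within the data shown here, no measured pair shows a change of this kind, so any forecast is rough. Among the measured compounds shown here, with only two values to go on, a moderate fall towards the number of compound 1, at 28700 nM, seems more likely than a further rise. The expected change is a 2.4-fold lower number from compound 2 to compound 3 (0.39 log units; beyond the scatter), which would mean stronger inhibition. Compound 3 is estimated at 35000 nM, within an expected range of 12000 nM to 90000 nM.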

Compound 3, half-maximal inhibitory concentration: > 100000 nM
Compound 3 was reported as a limit; the forecaster's own chance of this, stated with the estimate: 5%; middle value at least 2.8-fold (0.45 log units) from the limit.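

In this assay compound 3 stands at a limit and not at a number: the limit of > 100000 nM in this assay, at which 1 of the 3 values shown sits. Going by these compounds, putting furan-3-yl in place of 2-hydroxy-2-phenylpropyl on the carbonyl carbon gives an at least 1.1-fold higher number from compound 2 to compound 3 (0.06 log units; that floor lies within the scatter) and so brings no stronger inhibition, although the true size of this step stays unknown and its floor alone cannot separate the two compounds. The clearer reading comes from the change on the oxygen, where (furan-3-yl)carbonyl in place of 2-hydroxybutyl gives an at least 3.4-fold higher number from compound 1 to compound 3 (0.54 log units; beyond the scatter) and so weakens inhibition by a margin that can be read.

On these data alone, the step on the carbonyl carbon swaps the ring and removes the hydroxy group in a single change, so which of the two matters stays open. Also open, as far as these compounds go, is how an amine or a plain alkyl chain on that carbonyl carbon would read in this assay.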